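A Small Ester Swap at the Assay Limit

The source may hold more compounds than are shown below. What is called first, only, known or untested is meant among the compounds shown, and "the series" means these compounds.

In a functional assay on SK-BR-3 cells (Homo sapiens) for cytotoxicity, read by MTT assay, with a stated time of 72 h (a lower number here means that less compound is needed, a higher number that more compound is needed for the effect), compound 1 `CCc1cccc2c(OC)c(-c3occ(C)c3C(=S)OC)ccc12` gives 6.3 ug/mL. In the same test, compound 2 `CCc1cccc2c(OC)c(-c3occ(C)c3COC)ccc12` gives > 10 ug/mL. Going by these compounds, that value is a limit of the assay and not a number, so the true position of compound 2 remains unknown.

Compound 3 `CCc1cccc2c(OC)c(-c3occ(C)c3COC(C)=O)ccc12` carries acetyl in place of methyl on an oxygen on a saturated carbon, which turns methoxymethyl into acetoxymethyl (acetyl in place of methyl on an oxygen on a saturated carbon). For the measured compounds named here, only one measured step offers any guidance: an at least 1.5-fold higher number from compound 1 to compound 2 (0.20 log units; that floor lies within the scatter). It involves the same side group but a different exchange, so it bears on the new change only loosely. Its floor does not show a real difference between those two compounds. Going by the values given here, with so small a step from compound 1 to compound 2 as the sole guide, no clear shift is expected in this assay, and the new result may again be only a limit. The estimated change is a number no higher from compound 2 to compound 3 (the limit leaves the size open). For compound 3, the expected value is 10 ug/mL, with an estimated range from 4 ug/mL to 25 ug/mL.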

Compound 3, concentration for half-maximal effect: > 10 ug/mL
Compound 3 ended at the assay's limit (the forecaster's own chance of this, stated with the estimate: 55%); the middle value sits exactly at the limit.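

Replacing methoxymethyl with acetoxymethyl leaves the result at the same limit in this assay, so the step between these two compounds cannot be read, and neither a gain nor a loss can be assigned to acetyl in place of methyl. For the compounds shown here, the one step that can be read is an at least 1.5-fold higher number from compound 1 to compound 3 (0.20 log units; that floor lies within the scatter), so this second comparison with compound 1, like the first, shows no real difference. Little more can be said about this side group because the comparison stops at the same limit: the limit of > 10 ug/mL in this assay, at which 2 of the 3 values shown sit.

Where compound 2 and compound 3 truly stand remains open, as does whether methoxymethyl and acetoxymethyl differ at all in this test. Going by these compounds, it is also open whether another group in this place, such as an amine or a carboxylic acid, would give a number clearly apart from that of compound 1.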